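Benzyl ester series: amino in place of benzyloxy

This account rests on a few compounds, and the source may have more. Where it says the series, first, only, none or still open, it means among the compounds named here.

Measured compounds:
compound 1, `O=C(CN(c1nc(Cl)nc2[nH]cnc12)C1CC1)N[C@@H](CC(=O)OCc1ccccc1)C(=O)OCc1ccccc1` — 6.68%
compound 2, `C[C@@H](O)[C@H](NC(=O)CN(c1nc(Cl)nc2[nH]cnc12)C1CC1)C(=O)O` — 24%
compound 3, `O=C(O)CC[C@H](NC(=O)CN(c1nc(Cl)nc2[nH]cnc12)C1CC1)C(=O)O` — 29.5%

In a functional assay on the whole organism (Tail, strain ICR) with Mus musculus as the target, in the tail flick test, with a stated time of 150 min, at a dose of 25 umol/kg by the oral route (a lower number here means a weaker effect, a higher number a stronger effect of the compound at the dose given), compound 1 gives 6.68%, the lowest of the three numbers, and both other compounds lie beyond the scatter above it. Among the compounds with values here, compound 2 gives 24% and compound 3 gives 29.5%; the single step between measured compounds, a number 5.5 percentage points higher from compound 2 to compound 3 (within the scatter), is within the scatter and concerns a different part of the molecule, so it does not bear on the change considered here.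

Compound 4, `NC(=O)C[C@H](NC(=O)CN(c1nc(Cl)nc2[nH]cnc12)C1CC1)C(=O)OCc1ccccc1`, is not yet measured. Relative to compound 1 the change is amino in place of benzyloxy on a carbonyl carbon. Within the data shown here, no measured step covers this change on the shared core. Among the measured compounds shown here, what the numbers show is only that compound 1, carrying two benzyloxy groups, sits lowest, while compounds 2 and 3, which carry none, sit higher. Compound 4 keeps one benzyloxy, so a rise of moderate size from compound 1 is expected rather than a drop, with wide uncertainty. Compound 4 is estimated at 15% (range 4% to 30%), an expected step of a number 8.3 percentage points higher from compound 1 to compound 4 (within the scatter).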

Compound 4, a percentage reported as activity, at one dose (the size of the read-out at that dose, not a potency): 13.5%
Estimate against measurement, compound 4: 1.5 percentage points above; measured number inside the range.
By their numbers in this assay, from the lowest: compounds 1 and 4 (each within the scatter of the next); then compounds 2 and 3 (each within the scatter of the next).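

In this assay, within the data shown here, the first measured change on this carbonyl carbon, amino in place of benzyloxy, gives a number 6.8 percentage points higher from compound 1 to compound 4 (within the scatter). Replacing benzyloxy, with its six-membered aromatic ring, by the single nitrogen of amino therefore leaves compound 4 within the scatter of compound 1, and this one step shows no clear effect of benzyloxycarbonyl to carbamoyl at this position. No measurement is available to explain the result.

The compounds shown leave open how a carboxylic acid or a methylamino group on this same carbonyl carbon would read at this dose. They also leave open whether amino in place of the remaining benzyloxy of compound 4 would give a step beyond the scatter.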